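Acetyl in place of methylsulfanyl: what to expect

The source may report more compounds than this note shows. Statements on the series, on what has been measured and on what is new or still open speak of the compounds shown alone.

In a functional assay on SK-OV-3 cells (Homo sapiens) for antiproliferative activity, read by MTT assay, with a stated time of 72 h (on this read-out higher numbers stand for weaker inhibition and lower numbers for stronger inhibition), compound 1 `CC(C)c1cccc(NC(=O)CCc2cccc3c2B(O)OC3)c1` gives 510 nM and compound 2 `C#Cc1cccc(NC(=O)CCc2cccc3c2B(O)OC3)c1` gives 980 nM. Compound 3 `CSc1cccc(-c2cccc(NC(=O)CCc3cccc4c3B(O)OC4)c2)c1` gives 150 nM, the lowest of the three numbers. Compound 4 `CC(=O)c1cccc(-c2cccc(NC(=O)CCc3cccc4c3B(O)OC4)c2)c1` differs from compound 3 in one group: acetyl in place of methylsulfanyl on an aromatic carbon.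

Within the data shown here, no measured step changes this group alone. Introducing 3-(methylsulfanyl)phenyl gave a 3.4-fold lower number from compound 1 to compound 3 (0.53 log units; beyond the scatter) and a 6.5-fold lower number from compound 2 to compound 3 (0.82 log units; beyond the scatter), both modest, while a 1.9-fold higher number from compound 1 to compound 2 (0.28 log units; within the scatter) stayed within the scatter. Compound 4 keeps the phenyl ring of that group, so only a small rise is expected. In this assay the expected step is a 1.5-fold higher number from compound 3 to compound 4 (0.17 log units; within the scatter), which would not clearly exceed the scatter. For compound 4 the estimated value is 220 nM, with an expected range from 80 nM to 550 nM.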

Compound 4, half-maximal inhibitory concentration: 68 nM
For compound 4 the middle estimate is 3.2-fold (0.51 log units) above the measured one; measured number below the stated range.
By their numbers in this assay, from the lowest: compound 4; then compound 3; then compounds 1 and 2 (each within the scatter of the next).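

The group on this aromatic carbon of the added phenyl ring matters in this assay: acetyl in place of methylsulfanyl gave a 2.2-fold lower number from compound 3 to compound 4 (0.34 log units; beyond the scatter), the first step shown that changes this group alone. With 3-acetylphenyl, the steps from the smaller groups grow to a 14-fold lower number from compound 2 to compound 4 (1.16 log units; beyond the scatter) and a 7.5-fold lower number from compound 1 to compound 4 (0.88 log units; beyond the scatter). No measurement here accounts for these steps.

As far as these compounds go, whether an amine, a carboxylic acid or a longer chain on this carbon would lower the number further remains open. So does whether acetyl would give a similar step on another carbon of this ring.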